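This account rests on a few compounds, and the source may have more. Where it says the series, first, only, none or still open, it means among the compounds named here.

Among the measured compounds shown here, in an ADME assay on BEAS-2B cells (Homo sapiens) for cytotoxicity, read by fluorescence, with a stated time of 48 h (a higher number here means that more compound is tolerated, a lower number that less compound is tolerated), compound 3 `Cc1ccc(NC(=O)c2cc3n(n2)CCCN(C(=O)c2occc2C)C3)cc1` gives 30000 nM, the highest number of the three measured so far, ahead of compound 1 `Cc1ccoc1C(=O)N1CCCn2nc(C(=O)Nc3ccc(F)cc3F)cc2C1` at 5000 nM and compound 2 `Cc1ccccc1NC(=O)c1cc2n(n1)CCCN(C(=O)c1occc1C)C2` at 1100 nM. Compound 4 `Cc1ccoc1C(=O)N1CCCn2nc(C(=O)Nc3ccc(F)cc3)cc2C1` differs from compound 3 in one group, with fluoro in place of methyl on an aromatic carbon, para to a large group (fluoro in place of methyl on an aromatic carbon). For the measured compounds named here, no measured step makes this exact swap. The closest evidence is a 6.0-fold higher number from compound 1 to compound 3 (0.78 log units; beyond the scatter), a modest step beyond the scatter, with 4-methylphenyl in place of 2,4-difluorophenyl. The large 27-fold higher number from compound 2 to compound 3 (1.44 log units; beyond the scatter) compares only 2-methylphenyl with 4-methylphenyl, so it says little about replacing the methyl with fluoro, though it shows how widely this small series can spread. Going by the values given here, the one fluorinated compound measured, compound 1, stands lower than compound 3, so a modest fall in this assay is expected, with the estimated step being a 2.5-fold lower number from compound 3 to compound 4 (0.40 log units; beyond the scatter). The expected value for compound 4 is 12000 nM, within an estimated range from 3500 nM to 40000 nM.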

Compound 4, half-maximal cytotoxic concentration: 90000 nM
Compound 4: middle estimate off by 7.5-fold (0.88 log units), on the low side; the whole stated range lies below it.
By their numbers in this assay, from the lowest: compound 2; then compound 1; then compound 3; then compound 4.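

In this assay fluoro on this aromatic carbon, para to a large group, is tolerated better than methyl, with a 3.0-fold higher number from compound 3 to compound 4 (0.48 log units; beyond the scatter). Hydrogen in place of the other fluoro of the 2,4-difluorophenyl group gives an 18-fold higher number from compound 1 to compound 4 (1.26 log units; beyond the scatter) and the step of an 82-fold higher number from compound 2 to compound 4 (1.91 log units; beyond the scatter) widens the gap, so that the 4-fluorophenyl and 4-methylphenyl compounds stand above the 2,4-difluorophenyl and 2-methylphenyl compounds in this small set. Nothing shown here accounts for these differences in tolerance. The compounds shown leave open whether a 2-fluorophenyl group alone would bring the number down as far as in compound 1. They also leave open whether chloro or methoxy in the place of this fluoro would keep the number as high as in compound 4.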